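Same atoms joined differently, and a cytotoxicity limit

A few compounds are considered here, and "the series" means these few. Any claim that something is new, unique, unknown or untested is made for them only; others in the source may bear on it.

- Compound 1 `Cc1ccc2[nH]c(C)c(C(=O)NCc3ccc(N4CCC(c5ccc(OC(F)(F)F)cc5)CC4)cc3)c2c1`: "not determined" (no result reported)
- Compound 2 `Cc1nc2scc(C)n2c1C(=O)NCc1ccc(N2CCC(c3ccc(OC(F)(F)F)cc3)CC2)cc1`: > 100000 nM

Among the compounds with values here, the only measured compounds are tested in a toxicity assay on Vero cells (Chlorocebus sabaeus) for cytotoxicity, read by CCK-8 assay, with a stated time of 72 h; a higher number here means a weaker inhibitor, a lower number a stronger inhibitor. Compound 1 has the entry "not determined" (no result reported), so it offers no number for comparison. Compound 2 gives > 100000 nM, which is a limit of the assay and not a number.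

Compound 3 `Cc1cn2nc(C)c(C(=O)NCc3ccc(N4CCC(c5ccc(OC(F)(F)F)cc5)CC4)cc3)c2s1` has the same atoms as compound 2, joined differently: a group of 10 heavy atoms (7 carbon, 2 nitrogen, 1 sulfur; 2 five-membered aromatic rings with 2 hetero atoms each) in place of a group of 10 heavy atoms (7 carbon, 2 nitrogen, 1 sulfur; 2 five-membered aromatic rings with 2 hetero atoms each), on a carbonyl carbon. The change sits on a carbonyl carbon. Within the data shown here, no measured pair shows what such a change does, so the expectation rests on compound 2 alone, with its > 100000 nM. In this assay no change beyond the usual scatter is expected, an estimated at least 1.1-fold lower number from compound 2 to compound 3 (0.04 log units; that floor lies within the scatter). The assay may well report only a limit again. For compound 3 the estimate is 90000 nM, with an expected range of 35000 nM to 150000 nM.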

Compound 3, half-maximal inhibitory concentration: > 100000 nM
Compound 3 gave a limit, no number (the forecaster's own chance of this, stated with the estimate: 65%); middle value at least 1.1-fold (0.04 log units) from the limit.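

In this assay, no step can be read between compound 2 and compound 3, because both results are limits of the assay and not numbers: the limit of > 100000 nM in this assay, at which 2 of the 3 values shown sit.

The compounds shown leave open whether joining the same atoms differently, in the group on the carbonyl carbon, changes the cytotoxicity read-out at all.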